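Fluoro for trifluoromethyl on the amide aryl ring

The compounds below may be only part of what the source reports. "The series", "measured", "known", "first", "only" and "open" are said of these compounds alone.

compound 1, `Cn1cc2c(Cl)nc(NC(=O)c3ccc(F)cc3)nc2n1`: 31900 nM
compound 2, `CC(C)(C)Cn1cc2c(Cl)nc(NC(=O)c3ccc(C(F)(F)F)cc3)nc2n1`: 6600 nM

Of the compounds shown here, two have been measured in an assay on CHO cells for displacement of a labelled ligand from adenosine receptor A3 (Homo sapiens), read by scintillation counting, with a stated time of 3 h; on this read-out lower numbers stand for stronger inhibition and higher numbers for weaker inhibition. Compound 1 is `Cn1cc2c(Cl)nc(NC(=O)c3ccc(F)cc3)nc2n1` and in this assay compound 1 gives 31900 nM. Compound 2 is `CC(C)(C)Cn1cc2c(Cl)nc(NC(=O)c3ccc(C(F)(F)F)cc3)nc2n1` and in this assay compound 2 gives 6600 nM, the lowest of the two numbers; its gap to compound 1 lies beyond the scatter. The two differ in two places, so what the two values show cannot be assigned to one change alone.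

Compound 3 is `CC(C)(C)Cn1cc2c(Cl)nc(NC(=O)c3ccc(F)cc3)nc2n1`. It differs from compound 2 by fluoro in place of trifluoromethyl on an aromatic carbon. Among the compounds with values here, no measured pair isolates this change. Within the data shown here, since the only fluoro-bearing compound, compound 1, gives 31900 nM, a step towards weaker binding, modest and close to the scatter, is expected for compound 3, namely a 1.8-fold higher number from compound 2 to compound 3 (0.26 log units; within the scatter). Compound 3 is estimated at 12000 nM, within a range from 4000 nM to 40000 nM.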

Compound 3, inhibition constant: 5900 nM
Estimate against measurement, compound 3: 2.0-fold (0.31 log units) above; measured number inside the range.
By their numbers in this assay, from the lowest: compounds 3 and 2 (each within the scatter of the next); then compound 1.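

In this assay fluoro in place of trifluoromethyl on this aromatic carbon gives a 1.1-fold lower number from compound 2 to compound 3 (0.05 log units; within the scatter) and so, with this tert-butyl-bearing chain in place, the two groups cannot be told apart at this position. The gap between the first two compounds therefore does not go with the group on the aryl ring: tert-butyl in place of hydrogen on the saturated chain carbon bound to the aromatic nitrogen gives a 5.4-fold lower number from compound 1 to compound 3 (0.73 log units; beyond the scatter) and is the one change shown that lies beyond the scatter. Nothing at hand gives a reason for either step.

As far as these compounds go, whether the aromatic carbon stays as indifferent with a methoxy group, a nitrile or a carboxylic acid remains open. So does how the number behaves along the chain with an ethyl, an isopropyl or a cyclohexyl group in place of tert-butyl.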